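Trading 3-chlorophenyl for 4-hydroxyphenyl

This account rests on a few compounds, and the source may have more. Where it says the series, first, only, none or still open, it means among the compounds named here.

In a functional assay on LoVo cells (Homo sapiens) for inhibition, read by MTT assay, with a stated time of 24 h (on this read-out lower numbers stand for stronger inhibition and higher numbers for weaker inhibition), compound 1 `CC1(C)[C@H]2CC[C@]1(C)N(Cc1cn(-c3ccccc3C#N)nn1)C(=O)C2` gives 140 nM and compound 2 `CC1(C)[C@H]2CC[C@]1(C)N(Cc1cn(-c3cccc(Cl)c3)nn1)C(=O)C2` gives 70 nM. Among the measured compounds shown here, compound 2 therefore stands level, within the scatter, with the only other compound measured. Compound 3 `CC1(C)[C@H]2CC[C@]1(C)N(Cc1cn(-c3ccc(O)cc3)nn1)C(=O)C2` differs from compound 2 by 4-hydroxyphenyl in place of 3-chlorophenyl on an aromatic nitrogen, with 4-hydroxyphenyl in place of 3-chlorophenyl on an aromatic nitrogen. One measured step changes the group at this place: a 2.0-fold lower number from compound 1 to compound 2 (0.30 log units; within the scatter). For the measured compounds named here, no measured compound carries 4-hydroxyphenyl, so this is a thin guide. No step beyond the scatter, in either direction, is expected in this assay. The expected change is a 1.6-fold higher number from compound 2 to compound 3 (0.20 log units; within the scatter). The estimate for compound 3 is 110 nM, with a range from 30 nM to 400 nM.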

Compound 3, half-maximal inhibitory concentration: 410 nM
For compound 3 the middle estimate is 3.7-fold (0.57 log units) below the measured one, outside the stated range (above it).
By their numbers in this assay, from the lowest: compounds 2 and 1 (each within the scatter of the next); then compound 3.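

Changing this position to 4-hydroxyphenyl gives a 5.9-fold higher number from compound 2 to compound 3 (0.77 log units; beyond the scatter) and a 2.9-fold higher number from compound 1 to compound 3 (0.47 log units; beyond the scatter) in this assay. So this position can respond beyond the scatter, which the earlier step between the first two groups did not show. Unlike 3-chlorophenyl, 4-hydroxyphenyl carries a hydrogen-bond donor and acceptor, but no measurement here explains the weaker inhibition.

The compounds shown leave open whether the hydroxyl itself or its place on the phenyl ring matters more. A 3-hydroxyphenyl and a 4-chlorophenyl group would help separate those two possibilities.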